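The source may hold more compounds than are shown below. What is called first, only, known or untested is meant among the compounds shown, and "the series" means these compounds.

In an ADME assay on MDBK cells (Bos taurus) for cytotoxicity, read by MTT assay, with a stated time of 96 h (on this read-out lower numbers stand for higher toxicity in this test and higher numbers for lower toxicity in this test), compound 1 `FC(F)(F)c1cccc(NC(=S)Nc2ccc(Cl)cc2)c1` gives 17000 nM. Compound 2 `CC(=O)NC(=S)Nc1cccc(C(F)(F)F)c1` reads > 100000 nM, which is a limit of the assay. Compound 3 `C=C(C)CNC(=S)Nc1cccc(C(F)(F)F)c1` reads > 100000 nM, which is also a limit of the assay. Compound 3 therefore carries no exact number, and its place on the scale is the limit of > 100000 nM in this assay, at which 2 of the 3 values shown sit.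

Compound 4 `FC(F)(F)c1cccc(NC(=S)NCc2ccco2)c1` keeps the shared core, but furan-2-yl takes the place of 1-methylethenyl on a saturated chain carbon bound to an amide-type nitrogen: furan-2-yl in place of 1-methylethenyl on a saturated chain carbon bound to an amide-type nitrogen.

Among the measured compounds shown here, no measured step makes this exact change, but three steps concern the same amide-type nitrogen. Two start from compound 1, and both are beyond the scatter: an at least 5.8-fold higher number from compound 1 to compound 2 (0.76 log units; beyond the scatter) and an at least 5.8-fold higher number from compound 1 to compound 3 (0.76 log units; beyond the scatter). The third tells little, as it is a step that the two limits leave unreadable from compound 2 to compound 3. Compound 4 carries an aromatic ring, as compound 1 does with its 4-chlorophenyl, but on a saturated chain carbon, so it resembles compound 3 more closely in shape of attachment.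

A small downward move in the number is therefore expected, with lower toxicity in this test largely kept. The expected change is an at least 1.4-fold lower number from compound 3 to compound 4 (0.15 log units; that floor lies within the scatter). For compound 4 the estimated value is 70000 nM, with an expected range of 25000 nM to 100000 nM.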

Compound 4, half-maximal cytotoxic concentration: > 100000 nM
Compound 4: only a limit was reported; the forecaster's own chance of this, stated with the estimate: 55%; at least 1.4-fold (0.15 log units) between middle value and limit.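

Compound 4 places a ring on the amide-type nitrogen through a saturated chain carbon, and in this assay compound 4 reads > 100000 nM, which is a limit of the assay: the limit of > 100000 nM in this assay, at which 3 of the 4 values shown sit.

The swap of 4-chlorophenyl for (furan-2-yl)methyl gives an at least 5.8-fold higher number from compound 1 to compound 4 (0.76 log units; beyond the scatter), so among these compounds, having an aromatic ring in the group on this nitrogen does not by itself bring the number down to the level of compound 1. The steps among compound 2, compound 3 and compound 4 cannot be read: each of these compounds carries only a limit, so the acetyl, 2-methylprop-2-en-1-yl and (furan-2-yl)methyl groups cannot be ranked against each other in this test.

The compounds shown leave open which feature of the 4-chlorophenyl group goes with the lower number of compound 1: the chlorine, the kind of ring, or the ring sitting directly on the nitrogen. A plain phenyl or a 4-chlorobenzyl group on the same nitrogen would help to pull these features apart, and only a compound with an exact reading could show how far any such group moves the number.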